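Halogen pattern changes on the phenoxy group

The source may report more compounds than this note shows. Statements on the series, on what has been measured and on what is new or still open speak of the compounds shown alone.

- compound 1, `NC1=NC2(CCSCC2)N(OCCCOc2cccc(Cl)c2)C(N)=N1`: in an assay on isolated protein for inhibition of Dihydrofolate reductase (Homo sapiens), read by spectrophotometry, using NADPH, with stated times of 5 s and 6 min, tested at 5 uM (a higher number here means a stronger effect of the compound at the concentration tested, a lower number a weaker effect), compound 1 gives 88.3%.
- compound 2, `NC1=NC2(CCOCC2)N(OCCCOc2ccc(Cl)c(Cl)c2)C(N)=N1`: compound 2 reaches a limit of this assay, > 90%.
- compound 3, `NC1=NC2(CCOCC2)N(OCCCOc2cccc(Cl)c2Cl)C(N)=N1`: compound 3 gives 81.7%.

Of the two plain numbers, compound 1 has the higher one, but compound 3 sits within the usual scatter of it, so the two cannot be told apart on these data. The value of compound 2 is a limit and not a number (the limit of > 90% in this assay, at which 1 of the 3 values shown sits), so it gives no size to compare.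

Among the compounds with values here, the one measured step is a number at least 8.3 percentage points lower from compound 2 to compound 3 (that floor lies within the scatter), where 2,3-dichlorophenyl replaces 3,4-dichlorophenyl on an oxygen on a saturated carbon; its floor lies within the scatter, so it shows no effect that can be separated from noise.

Compound 4, `NC1=NC2(CCSCC2)N(OCCCOc2ccccc2Br)C(N)=N1`, is to be measured in this assay. It differs from compound 1 by 2-bromophenyl in place of 3-chlorophenyl on an oxygen on a saturated carbon. The step from compound 2 to compound 3 is the only measured one that also moves halogen substitution on this phenyl, and it was small, so the expected step of a number 6.3 percentage points lower from compound 1 to compound 4 (within the scatter) is none beyond the scatter. Compound 4 is therefore estimated at 82%, with a range from 62% to 92%.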

Compound 4, a percentage reported as inhibition, at one concentration (the size of the read-out at that concentration, not a potency): 88.7%
Compound 4: middle estimate off by 6.7 percentage points, on the low side; low and high end bracket the measured number.
By their numbers in this assay, from the lowest: compounds 3, 1 and 4 (each within the scatter of the next). At a limit, above all of these: compound 2.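

In this assay the exchange of 3-chlorophenyl for 2-bromophenyl is a step of a number 0.4 percentage points higher from compound 1 to compound 4 (within the scatter) and shows no effect that can be separated from noise. Unlike the earlier step on this phenyl, this one is read from two plain numbers, so it has a definite size and not just a floor, and it is the first measured on the core of compound 1. It also changes the halogen and its place on the phenyl together, and the read-out stays flat through that double change, although a single pair cannot show how far this holds for other halogen patterns. No measured value shown here offers a reason for this flat step.

Because chlorine and bromine change along with their place on the ring in this one step, the two changes stay unresolved, and 2-chlorophenyl or 3-bromophenyl on the same core would separate them. Also open, from the compounds shown here alone, is whether a phenyl carrying an amine or a carboxylic acid in place of the halogen, or a longer chain to the phenoxy group, would give a step beyond the scatter.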